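The source may report more compounds than this note shows. Statements on the series, on what has been measured and on what is new or still open speak of the compounds shown alone.

Compound 3 `CN(C)c1ccc(C2CC(c3ccc(-n4cncn4)cc3)=NN2C(=O)c2ccc(C(F)(F)F)cc2)cc1` gives 7% in a functional assay on HCC1806 cells (Homo sapiens) for inhibition, read by sulforhodamine B assay, tested at 10 uM; on this read-out lower numbers stand for less inhibition and higher numbers for more inhibition at the one concentration tested (going by the name of the read-out). On the three numbers in hand it stands at the top, but the nearest, compound 1 `CN(C)c1ccc(C2CC(c3ccc(-n4cncn4)cc3)=NN2)cc1` with 6.8%, lies within the usual scatter of it, and only compound 2 `CN1CCN(c2ccc(C3=NN(S(C)(=O)=O)C(c4ccc(N(C)C)cc4)C3)cc2)CC1` with -18.5% is separated from it beyond the scatter. For the measured compounds named here, the one step measured, a number 0.2 percentage points higher from compound 1 to compound 3 (within the scatter), came from putting the (4-(trifluoromethyl)phenyl)carbonyl onto the amine nitrogen in the ring and changed nothing beyond the scatter. Compound 4 `CN(C)c1ccc(C2CC(c3ccc(-n4cncn4)cc3)=NN2S(C)(=O)=O)cc1` now differs from compound 3 in that (methylsulfonyl in place of (4-(trifluoromethyl)phenyl)carbonyl on an amine nitrogen in a ring). Compound 2 also carries a methylsulfonyl on its ring nitrogen, together with a different group elsewhere, and its value is the lowest of the three. Going by the values given here, since the only measured step on this nitrogen was flat, the expected step of a number 7 percentage points lower from compound 3 to compound 4 (within the scatter) is small, leaning slightly downward in view of compound 2, and not beyond the scatter. Compound 4 is therefore estimated at 0%, within -20% to 15%.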

Compound 4, a percentage reported as inhibition, at one concentration (the size of the read-out at that concentration, not a potency): 10.8%
Compound 4: middle estimate off by 10.8 percentage points, on the low side; low and high end bracket the measured number.
By their numbers in this assay, from the lowest: compound 2; then compounds 1, 3 and 4 (each within the scatter of the next).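

In this assay the amine nitrogen in the ring accepts methylsulfonyl with no change beyond the scatter, whether it replaces (4-(trifluoromethyl)phenyl)carbonyl, with a number 3.8 percentage points higher from compound 3 to compound 4 (within the scatter), or hydrogen, with a number 4 percentage points higher from compound 1 to compound 4 (within the scatter), so hydrogen and both of these groups read alike at this position. The methylsulfonyl therefore does not go with a low value on its own: with it held constant, 1H-1,2,4-triazol-1-yl in place of 4-methylpiperazin-1-yl on an aromatic carbon gives a number 29.3 percentage points higher from compound 2 to compound 4 (beyond the scatter), which ties the low value of compound 2 to the 4-methylpiperazin-1-yl group. Nothing available here explains either finding. Still open, on these data alone, is whether an acetyl group or a longer alkyl chain on this ring nitrogen would leave the number as flat. Also open, as far as these compounds go, is whether an amine or a carboxylic acid in place of the 1H-1,2,4-triazol-1-yl would move it beyond the scatter.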